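This account rests on a few compounds, and the source may have more. Where it says the series, first, only, none or still open, it means among the compounds named here.

Measured so far:
compound 1, `Cc1ccc(C(=O)/C=C/c2ccc(/C=N/NC(=O)c3ccncc3)cc2)c(C)c1`, 58.5%
compound 2, `O=C(N/N=C/c1ccc(/C=C/C(=O)c2ccccc2F)cc1)c1ccncc1`, 51.3%
compound 3, `N=C(N)N/N=C/c1ccc(/C=C/C(=O)c2cccc(Cl)c2)cc1`, 80.7%

In a functional assay on the whole organism (Ear) for inhibition, with Mus musculus as the target, with a stated time of 30 min, at a dose of 100 mg/kg by the intraperitoneal route (on this read-out higher numbers stand for more inhibition at the one dose given (going by the name of the read-out) and lower numbers for less inhibition), compound 3 gives 80.7%, the highest of the three numbers; compounds 1 and 2 both sit more than the usual scatter below it.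

Compound 4, `N=C(N)N/N=C/c1ccc(/C=C/C(=O)c2ccc(Cl)cc2Cl)cc1`, is not yet measured. It differs from compound 3 by 2,4-dichlorophenyl in place of 3-chlorophenyl on a carbonyl carbon, the entering group being 2,4-dichlorophenyl, the leaving group 3-chlorophenyl, both on the carbonyl carbon.

For the measured compounds named here, the one measured step at that same place is a number 7.2 percentage points lower from compound 1 to compound 2 (within the scatter), a swap of the aryl group on the carbonyl carbon that stayed within the scatter. On that basis the aryl swap from compound 3 to compound 4 is expected to bring little movement in this assay, with a number 3.7 percentage points lower from compound 3 to compound 4 (within the scatter) as the expected step. Compound 4 is therefore estimated at 77%, in a range from 60% to 92%.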

Compound 4, a percentage reported as inhibition, in the whole organism at one dose (the size of the read-out at that dose, not a potency): 92.5%
For compound 4 the middle estimate is 15.5 percentage points below the measured one; measured number above the stated range.
By their numbers in this assay, from the lowest: compounds 2 and 1 (each within the scatter of the next); then compound 3; then compound 4.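

In this assay, the aryl swap on the carbonyl carbon gives a number 11.8 percentage points higher from compound 3 to compound 4 (beyond the scatter), so this place can move the read-out, which the earlier swap, with a number 7.2 percentage points lower from compound 1 to compound 2 (within the scatter), did not show. The change from 3-chlorophenyl to 2,4-dichlorophenyl both adds a chlorine and alters the substitution pattern, and this single step does not separate the two. No measured data on hand account for the gain.

Still open, as far as these compounds go, is whether an unsubstituted phenyl, or a phenyl carrying a methoxy group or an amine, would hold the number at this place.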